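This account rests on a few compounds, and the source may have more. Where it says the series, first, only, none or still open, it means among the compounds named here.

In a functional assay on A549 cells (Homo sapiens) for cytotoxicity, read by MTT assay, with a stated time of 48 h (a higher number here means a weaker inhibitor, a lower number a stronger inhibitor), compound 1 `Cc1cc2cc(N/C=C\C(=O)c3nc(-c4ccc(F)cc4)n4ccccc34)ccc2[nH]1` is known only as a limit and not as a number, namely > 30000 nM. The same holds for compound 2 `COc1ccc(N/C=C\C(=O)c2nc(-c3ccccc3)n3ccccc23)cc1`, which in this assay gives the limit > 30000 nM. Compound 3 `O=C(/C=C\Nc1cnc2ccccc2c1)c1nc(-c2ccccc2)n2ccccc12` likewise gives in this assay the limit > 30000 nM. For the measured compounds named here, the one measured step between these compounds, a step that the two limits leave unreadable from compound 2 to compound 3, therefore cannot be read, and no measured step speaks directly to the change from compound 1 to compound 4. All that this assay offers is the limit of > 30000 nM in this assay, at which 3 of the 3 values shown sit.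

Compound 4 `O=C(/C=C\Nc1ccc(F)cc1)c1nc(-c2ccc(F)cc2)n2ccccc12` differs from compound 1 in one place: 4-fluorophenyl in place of 2-methyl-1H-indol-5-yl on an amine nitrogen. Going by the values given here, no measured step bears on this change, so its size is expected to stay within the scatter, because the limit of > 30000 nM in this assay, at which 3 of the 3 values shown sit, gives no number from which a direction could be read. The step from compound 1 to compound 4 is thus estimated as a number no higher from compound 1 to compound 4 (the limit leaves the size open). For compound 4 this assay is expected to give 30000 nM, within a range of 10000 nM to 100000 nM, and most likely again only a limit.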

Compound 4, half-maximal inhibitory concentration: 13200 nM
Compound 4: middle estimate off by 2.3-fold (0.36 log units), on the high side; the measured number falls inside the stated range.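

In this assay, for the compounds shown here, putting 4-fluorophenyl in place of 2-methyl-1H-indol-5-yl on the amine nitrogen gives an at least 2.2-fold lower number from compound 1 to compound 4 (0.35 log units; beyond the scatter), the first step in this set that can be read at all. It shows that the group at this place can move the read-out, with the lower number going to the group that has fewer heavy atoms and no hydrogen-bond donor, though this one step cannot tell these differences apart. Compound 1 remains known only as a limit, as do the other compounds that do not give a number: the limit of > 30000 nM in this assay, at which 3 of the 4 values shown sit.

From the compounds shown here alone, what a plain phenyl, or a phenyl carrying a carboxylic acid, would give on this amine nitrogen stays open. Also open, going by these compounds, is whether the same change would lower the number on a core without the 4-fluorophenyl group that compound 1 and compound 4 share.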